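A few compounds are considered here, and "the series" means these few. Any claim that something is new, unique, unknown or untested is made for them only; others in the source may bear on it.

Compound 1 `COc1cc(C)c(S(=O)(=O)N(C)CCOCC(=O)N2CCC(C(C)(C)CN(C)C)CC2)c(C)c1` sits in the middle of three measured compounds in an ADME assay on microsomes from liver (Homo sapiens) for metabolic stability, with a stated time of 30 min, tested at 1 uM; on this read-out lower numbers stand for a less stable compound and higher numbers for a more stable compound. Compound 1 gives 36%, the second highest of the three numbers. Its nearest neighbour is compound 2 `COc1cc(C)c(S(=O)(=O)N(C)CCOCC(=O)N2CCN(C3CCN(C4CC4)CC3)CC2)c(C)c1`, which gives 6%, a lower number and beyond the usual scatter, so compound 2 is the less stable of the two. The furthest is compound 3 `CN(Cc1ccc(C2=NCCN2)cc1)C(=O)COCCN(C)S(=O)(=O)c1ccc(OC(F)(F)F)cc1`, which gives 86%, a higher number and again well beyond the scatter; compound 3 is the most stable of the three. No two of these measured compounds differ in a single place, so the gaps between them cannot be traced to one structural change.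

Compound 4 `COc1cc(C)c(S(=O)(=O)N(C)CCOCC(=O)N2CCC(C3CCN(C)CC3)CC2)c(C)c1` differs from compound 1 in one place: 1-methylpiperidin-4-yl in place of 1-((dimethylamino)methyl)-1-methylethyl on a saturated ring carbon. Within the data shown here, no measured pair shows what such an exchange does in this assay, so there is no direct guide to the size of the step. The change is expected to move the number only modestly, and the step from compound 1 to compound 4 is estimated at a number 6 percentage points lower from compound 1 to compound 4 (within the scatter), likely within or close to the scatter. Compound 4 is accordingly expected to give about 30%, with a plausible range from 12% to 55%.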

Compound 4, percent of the compound remaining: 23%
For compound 4 the middle estimate is 7 percentage points above the measured one; measured number inside the range.
By their numbers in this assay, from the lowest: compound 2; then compound 4; then compound 1; then compound 3.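

Among these compounds, exchanging 1-((dimethylamino)methyl)-1-methylethyl for 1-methylpiperidin-4-yl on a saturated ring carbon gives the first comparison in this set that isolates a single change, and in this assay it gives a number 13 percentage points lower from compound 1 to compound 4 (beyond the scatter). The two groups have the same counts of heavy atoms, carbons, nitrogens and hydrogen-bond acceptors, but the entering group holds them in a six-membered non-aromatic ring, whereas the leaving group has no ring. At this position, then, a change in how the same atom counts are arranged is enough to take the number beyond the usual scatter, although no measurement here accounts for the direction or size of the step.

From the compounds shown here alone, this is a single pair on a single core, so it remains open whether the same exchange would have a similar effect on a different core. Going by these compounds, it also remains open how a cyclohexyl group, which has no ring nitrogen, or a morpholine ring would compare at this position with 1-methylpiperidin-4-yl.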